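Fluoro on the benzyl arm of the shared core

The compounds below may be only part of what the source reports. "The series", "measured", "known", "first", "only" and "open" are said of these compounds alone.

Measured so far:
- compound 1 `COc1ccc(CNCc2c(OC)cc(Oc3cccc(Nc4ccccc4)c3)cc2OC)cc1`: 6970 nM
- compound 2 `COc1cc(Oc2cccc(Nc3ccccc3)c2)cc(OC)c1CNCc1ccccc1`: 7490 nM
- compound 3 `COc1ccc(CCCNCc2c(OC)cc(Oc3ccc(Nc4ccccc4)cc3)cc2OC)cc1`: 14600 nM

In a functional assay on SW-620 cells (Homo sapiens) for inhibition, read by MTT assay, with a stated time of 72 h (a higher number here means a weaker inhibitor, a lower number a stronger inhibitor), compound 2 gives 7490 nM, the second highest of the three numbers. Among the compounds with values here, its nearest neighbour is compound 1; the only single-point step in the set runs a 1.1-fold higher number from compound 1 to compound 2 (0.03 log units; within the scatter), hydrogen in place of methoxy on an aromatic carbon of the benzyl arm. Compound 3 differs from compound 2 in more than one place, so only its number is set beside it: compound 3 gives 14600 nM, and the gap to compound 2 is within the scatter.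

The next compound, compound 4 `COc1cc(Oc2cccc(Nc3ccccc3)c2)cc(OC)c1CNCc1ccc(F)cc1`, carries fluoro in place of hydrogen on an aromatic carbon of the benzyl ring, para to a large group; read one bond further out, benzyl becomes 4-fluorobenzyl. Within the data shown here, no measured step bears directly on a fluoro substituent. Among the measured compounds shown here, the one step that touches the same ring, from compound 1 to compound 2, stayed within the scatter, and nothing in the set points to a large move in either direction.

The expectation for compound 4 in this assay is therefore a change of about a 1.1-fold lower number from compound 2 to compound 4 (0.03 log units; within the scatter), that is, none beyond the scatter. Compound 4 is estimated at 7000 nM, with a range from 3500 nM to 14000 nM.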

Compound 4, half-maximal inhibitory concentration: 6770 nM
For compound 4 the middle estimate is 1.0-fold (0.01 log units) above the measured one; low and high end bracket the measured number.
By their numbers in this assay, from the lowest: compounds 4, 1, 2 and 3 (each within the scatter of the next, the first and the last beyond it).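

In this assay, fluoro in place of hydrogen on an aromatic carbon of the benzyl ring, para to a large group, gives a 1.1-fold lower number from compound 2 to compound 4 (0.04 log units; within the scatter) and so puts benzyl and 4-fluorobenzyl within the scatter of each other. Fluoro in place of methoxy at the same place gives a 1.0-fold lower number from compound 1 to compound 4 (0.01 log units; within the scatter) and also stays within the scatter. With compound 2, compound 1 and compound 4 all within the scatter of one another, hydrogen, methoxy and fluoro at this place cannot be told apart in this cell read-out, and the place now has three substituents behind that reading rather than two. Nothing available on these compounds offers a reason for that flat reading.

The compounds shown leave open whether a group of another kind at this same place, such as an amine or a carboxylic acid, would separate from hydrogen, methoxy and fluoro. They also leave open whether the same flat reading holds for fluoro or methoxy on the other carbons of the benzyl ring.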